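A few compounds are considered here, and "the series" means these few. Any claim that something is new, unique, unknown or untested is made for them only; others in the source may bear on it.

Compound 1 `CC(C)(C)c1ccc(C(=O)N2CCC3(CC2)C(=O)N(CC(=O)NCCO)CN3c2ccccc2)cc1` gives 1000 nM in an assay on HEK293 cells for displacement of a labelled ligand from NPC1-like intracellular cholesterol transporter 1 (Homo sapiens); on this read-out lower numbers stand for stronger inhibition and higher numbers for weaker inhibition.
Compound 2 `CC(C)(C)c1ccc(C(=O)N2CCC3(CC2)C(=O)N(CC(=O)NCCC(=O)O)CN3c2ccccc2)cc1` gives 11400 nM in this assay.
Compound 3 `CC(C)(C)c1ccc(C(=O)N2CCC3(CC2)C(=O)N(CC(=O)NCCCNS(C)(=O)=O)CN3c2ccccc2)cc1` gives 10400 nM in this assay.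

Among these three, compound 3 has the second highest number. Its nearest neighbour is compound 2, with a 1.1-fold lower number from compound 2 to compound 3 (0.04 log units; within the scatter), and the furthest is compound 1, with a 10-fold higher number from compound 1 to compound 3 (1.02 log units; beyond the scatter).

Compound 4 `CC(C)(C)c1ccc(C(=O)N2CCC3(CC2)C(=O)N(CC(=O)N2CCCC(CO)C2)CN3c2ccccc2)cc1` has not yet been measured. The change from compound 3 is 3-(hydroxymethyl)piperidin-1-yl in place of (3-(methanesulfonamido)propyl)amino on a carbonyl carbon. Going by the values given here, no measured step makes this exact change. Among the compounds with values here, the steps that bear on it alter only the end of the same chain: an 11-fold higher number from compound 1 to compound 2 (1.06 log units; beyond the scatter) and a 10-fold higher number from compound 1 to compound 3 (1.02 log units; beyond the scatter). Both are large and both point the same way: of the three ends tried, the hydroxy of compound 1 gave by far the lowest number. The group entering in compound 4 carries a hydroxymethyl on a six-membered ring, so some of that benefit may return, though the rest of the group differs from anything measured. A moderate fall is therefore expected, a 3.0-fold lower number from compound 3 to compound 4 (0.47 log units; beyond the scatter), but with wide uncertainty. The estimate for compound 4 in this assay is 3500 nM, with a range from 800 nM to 15000 nM.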

Compound 4, half-maximal inhibitory concentration: 8200 nM
The estimate for compound 4 lay 2.3-fold (0.37 log units) below the measured number; the measured number falls inside the stated range.
By their numbers in this assay, from the lowest: compound 1; then compounds 4, 3 and 2 (each within the scatter of the next).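

A hydroxy group at the end of this side chain is not enough on its own to restore the lowest number in this assay: with 3-(hydroxymethyl)piperidin-1-yl on the same carbonyl carbon, compound 4 remains well apart from compound 1 (an 8.2-fold higher number from compound 1 to compound 4 (0.91 log units; beyond the scatter)). It also cannot be told apart from the methanesulfonamide compound (a 1.3-fold lower number from compound 3 to compound 4 (0.10 log units; within the scatter)) or the carboxylic acid compound (a 1.4-fold lower number from compound 2 to compound 4 (0.14 log units; within the scatter)), so three quite different ends now give matching results, and only the (2-hydroxyethyl)amino end of compound 1 stands apart. Nothing shown here explains this behaviour.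

Still open, on these data alone, is whether the ring itself or the place of the hydroxy group on it accounts for the gap to compound 1. A (3-hydroxypropyl)amino chain or 4-(hydroxymethyl)piperidin-1-yl on the same carbonyl carbon would help to separate these two possibilities.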